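Swapping fluoro for chloro on compound 3

This account rests on a few compounds, and the source may have more. Where it says the series, first, only, none or still open, it means among the compounds named here.

Compound 1 `CCOC(=O)C1=C(C)N(c2ccccc2)C=CC1c1ccccc1`, compound 2 `CCOC(=O)C1=C(C)N(c2ccc(C)cc2)C=CC1c1ccccc1` and compound 3 `CCOC(=O)C1=C(C)N(c2ccc(F)cc2)C=CC1c1ccccc1` share one core and differ only in a single group on an aromatic carbon. In a functional assay, tested at 100 ug/mL (a lower number here means a stronger effect, a higher number a weaker effect of the compound at the concentration tested), compound 1 gives -13.8%. Compound 2 gives -20.7%, and compound 3 gives -10.9%. On these numbers compound 3 stands highest of the three, yet its gaps to the others, a number 2.9 percentage points higher from compound 1 to compound 3 (within the scatter) and a number 9.8 percentage points higher from compound 2 to compound 3 (within the scatter), are within the scatter, as is a number 6.9 percentage points lower from compound 1 to compound 2 (within the scatter). The unmeasured compound 4 `CCOC(=O)C1=C(C)N(c2ccc(Cl)cc2)C=CC1c1ccccc1` differs from compound 3 by chloro in place of fluoro on an aromatic carbon. The measured steps that bear on this are the two that changed the same aromatic carbon, a number 2.9 percentage points higher from compound 1 to compound 3 (within the scatter) and a number 9.8 percentage points higher from compound 2 to compound 3 (within the scatter); neither left the scatter, so hydrogen, methyl and fluoro at that place all gave read-outs within the scatter of one another. Chloro itself is untested, so the expectation rests on that flat picture. The step is therefore expected to be none beyond the scatter, a number 2.1 percentage points lower from compound 3 to compound 4 (within the scatter). Compound 4 is estimated at -13%, in the range -30% to 5%.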

Compound 4, a percentage reported as activity, at one concentration (the size of the read-out at that concentration, not a potency): -20.8%
Compound 4: the middle estimate sits 7.8 percentage points above what was measured, within the range that was stated.
By their numbers in this assay, from the lowest: compounds 4, 2, 1 and 3 (each within the scatter of the next).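

In this assay, chloro on this aromatic carbon, para to a large group, stays level with every group tested there: a number 9.9 percentage points lower from compound 3 to compound 4 (within the scatter), a number 0.1 percentage points lower from compound 2 to compound 4 (within the scatter) and a number 7 percentage points lower from compound 1 to compound 4 (within the scatter). Hydrogen, methyl, fluoro and chloro have now all been placed on this carbon, and none of the six steps among compounds 1, 2, 3 and 4 leaves the scatter, so the change from 4-fluorophenyl to 4-chlorophenyl adds a halogen to the flat picture without breaking it. Nothing is available that would account for these read-outs.

On these data alone, whether an amine or a carboxylic acid on this carbon would move the read-out beyond the scatter remains open. So does whether chloro would behave the same way on another carbon of that ring.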